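Swapping the Amine Group on the Thiocarbonyl Carbon of Compound 2

The source may hold more compounds than are shown below. What is called first, only, known or untested is meant among the compounds shown, and "the series" means these compounds.

Compound 2 `CCOC(=O)c1cc(=O)c2cc(CSC(=S)N(C)c3ccccc3)ccc2o1` sits toward the weak end of the three chromone-type compounds measured in a functional assay on MDA-MB-435S cells (Homo sapiens) for antiproliferative activity, read by MTT assay, with a stated time of 72 h (a lower number here means a stronger inhibitor, a higher number a weaker inhibitor), where compound 2 gives 13500 nM. Compound 3 `CC(C)N(C(=S)SCc1oc2ccccc2c(=O)c1Cl)C(C)C` gives 23600 nM in this assay, a number within the scatter of that of compound 2, while compound 1 `O=c1c(CSC(=S)N2CCCCC2)coc2cc(Cl)ccc12` gives 240 nM, far lower than either. Compound 4 `CCOC(=O)c1cc(=O)c2cc(CSC(=S)N3CCCC3)ccc2o1` has not been measured; it differs from compound 2 by pyrrolidin-1-yl in place of methyl(phenyl)amino on a thiocarbonyl carbon. Among the compounds with values here, with no step between measured compounds available to anchor the change, he expects only a modest shift toward stronger inhibition, estimated as a 1.7-fold lower number from compound 2 to compound 4 (0.23 log units; within the scatter). For compound 4 he estimates a value of 8000 nM, with a range from 2000 nM to 30000 nM.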

Compound 4, half-maximal inhibitory concentration: 3400 nM
The estimate for compound 4 lay 2.4-fold (0.37 log units) above the measured number, within the range that was stated.
By their numbers in this assay, from the lowest: compound 1; then compound 4; then compounds 2 and 3 (each within the scatter of the next).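

In this assay, pyrrolidin-1-yl in place of methyl(phenyl)amino on a thiocarbonyl carbon gives a 4.0-fold lower number from compound 2 to compound 4 (0.60 log units; beyond the scatter) with the rest of the molecule unchanged, so the amine group at this position can move the number beyond the scatter. The six-membered aromatic ring that leaves is not needed for the antiproliferative activity seen in this pair. Nothing available explains the shift.

This single step swaps the phenyl and methyl groups and the ring form together, and it does not separate their contributions. As far as these compounds go, whether piperidin-1-yl, morpholin-4-yl or dimethylamino on the same carbon would give a lower or higher number remains open.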